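The source may hold more compounds than are shown below. What is called first, only, known or untested is meant among the compounds shown, and "the series" means these compounds.

Measured so far:
compound 1 `COc1ccc(C(=O)/C=C/c2ccc(C(F)(F)F)cc2)c2c1C=CC(C)(C)O2`; in a functional assay on HepG2 cells (Homo sapiens) for antiproliferative activity, read by MTT assay, with a stated time of 24 h (on this read-out lower numbers stand for stronger inhibition and higher numbers for weaker inhibition), compound 1 gives > 10000 nM, which is a limit of the assay rather than a number.
compound 2 `COc1ccc(C(=O)/C=C/c2cccc(C(F)(F)F)c2)c2c1C=CC(C)(C)O2`; in this assay compound 2 gives > 10000 nM, again a limit rather than a number.

Compound 2 therefore stands at the edge of what this assay can report: its result is only a limit, and it shares that position with compound 1, since both values sit at the limit of > 10000 nM in this assay, at which 2 of the 2 values shown sit. Among the compounds with values here, no step between the two measured compounds can be sized, so nothing here says how a change on this ring moves potency. Compound 3 `COc1ccc(C(=O)/C=C/c2cccc(O)c2)c2c1C=CC(C)(C)O2` has not yet been tested. It differs from compound 2 by hydroxy in place of trifluoromethyl on an aromatic carbon. Within the data shown here, with no measured step to lean on, the step that the limit leaves unreadable from compound 2 to compound 3 in this assay is expected to be small and likely not beyond the scatter, though a reportable number becomes somewhat more likely. Compound 3 is expected to give 15000 nM in this assay, between 4000 nM and 50000 nM.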

Compound 3, half-maximal inhibitory concentration: > 10000 nM
Compound 3: only a limit was reported; the forecaster's own chance of this, stated with the estimate: 65%; the middle value is on the limit's open side.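

In this assay, within the data shown here, compound 3, like compound 2, gives only a limit, so no step between compound 2 and compound 3 can be read: the limit of > 10000 nM in this assay, at which 3 of the 3 values shown sit. The compounds shown leave open whether exchanging trifluoromethyl for hydroxy changes potency at all, and how far either compound lies from that limit.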